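The source may report more compounds than this note shows. Statements on the series, on what has been measured and on what is new or still open speak of the compounds shown alone.

In a functional assay on L1210 cells (Mus musculus) for inhibition (on this read-out lower numbers stand for stronger inhibition and higher numbers for weaker inhibition), compound 1 (`COc1nc(O)c2cc(CNc3ccc(C(=O)NC(CCC(=O)O)C(=O)O)cc3)ccc2n1`) gives 6400 nM and compound 2 (`COc1nc(O)c2cc(CN(C)c3ccc(C(=O)NC(CCC(=O)O)C(=O)O)cc3)ccc2n1`) gives 7000 nM, so the two stand level within the scatter. Compound 3 (`COc1nc(O)c2cc(CN(CCCO)c3ccc(C(=O)NC(CCC(=O)O)C(=O)O)cc3)ccc2n1`) changes compound 2 at that same nitrogen: 2-hydroxyethyl in place of hydrogen on a saturated chain carbon bound to a nitrogen on an aromatic ring, which turns methyl into 3-hydroxypropyl. Going by the values given here, the one measured step bearing on this is a 1.1-fold higher number from compound 1 to compound 2 (0.04 log units; within the scatter), and it stayed within the scatter. Among the compounds with values here, no measured compound carries a hydroxyl-bearing chain, so this guide is limited. The expected change in this assay is a 1.2-fold lower number from compound 2 to compound 3 (0.07 log units; within the scatter), no step beyond the scatter. For compound 3 the estimated value is 6000 nM, with an expected range of 2500 nM to 15000 nM.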

Compound 3, half-maximal inhibitory concentration: 80000 nM
Beside the measured number, compound 3's estimate is 13-fold (1.12 log units) below it, outside the stated range (above it).
By their numbers in this assay, from the lowest: compounds 1 and 2 (each within the scatter of the next); then compound 3.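

In this assay the change from methyl to 3-hydroxypropyl on this nitrogen brings an 11-fold higher number from compound 2 to compound 3 (1.06 log units; beyond the scatter) and 3-hydroxypropyl in place of hydrogen brings a 13-fold higher number from compound 1 to compound 3 (1.10 log units; beyond the scatter) so this position, which showed no shift from hydrogen to methyl, does respond to its substituent. Nothing available explains this loss of inhibition.

The compounds shown leave open whether the step goes with the chain or with its hydroxyl, a question a plain propyl chain on this nitrogen would address. They also leave open how an amine or a carboxylic acid at the chain end would read.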